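Methyl on the core of compound 1

This account rests on a few compounds, and the source may have more. Where it says the series, first, only, none or still open, it means among the compounds named here.

For the measured compounds named here, in a functional assay on U-251 cells (Homo sapiens) (on this read-out higher numbers stand for weaker inhibition of growth and lower numbers for stronger inhibition of growth), compound 1 `Oc1cc(-c2ccc(Cl)cc2)nc2ncccc12` gives 39800 nM, the higher of the two numbers so far. Compound 3 `Cc1ccnc2nc(-c3ccc(Cl)cc3)cc(O)c12` differs from it by methyl in place of hydrogen on an aromatic carbon, a methyl in place of hydrogen on an aromatic carbon, opposite the ring nitrogen. Going by the values given here, one measured step bears on this: compound 2 `Cc1cnc2nc(-c3ccc(Cl)cc3)cc(O)c2c1` gives 3020 nM with the same kind of change, and a 13-fold lower number from compound 1 to compound 2 (1.12 log units; beyond the scatter) is large. With a single precedent and a different structure, a smaller step in the same direction is expected, estimated as a 4.0-fold lower number from compound 1 to compound 3 (0.60 log units; beyond the scatter). For compound 3 the expected value is 10000 nM, with an estimated range of 3000 nM to 35000 nM.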

Compound 3, concentration for 50% growth inhibition: 4570 nM
Beside the measured number, compound 3's estimate is 2.2-fold (0.34 log units) above it, within the range that was stated.
By their numbers in this assay, from the lowest: compounds 2 and 3 (each within the scatter of the next); then compound 1.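

In this assay, methyl in place of hydrogen on this aromatic carbon, opposite the ring nitrogen, also brings a drop, with an 8.7-fold lower number from compound 1 to compound 3 (0.94 log units; beyond the scatter). The effect on the core of compound 1 is thus not tied to a single carbon: compound 2 at 3020 nM and compound 3 at 4570 nM lie within the scatter of each other. Nothing available explains the step.

Open, as far as these compounds go, is whether ethyl, methoxy or an amine on this carbon would keep the lower number. Also open, from the compounds shown here alone, is what methyl on both carbons would give.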